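Thiophene in Place of Dimethoxyphenyl on a Shared Core

A few compounds are considered here, and "the series" means these few. Any claim that something is new, unique, unknown or untested is made for them only; others in the source may bear on it.

Compound 1 `COc1ccc(-c2nc3cccc(-c4cc(OC)c(OC)c(OC)c4)c3o2)cc1OC` gives 1300 nM in a functional assay on U-251 cells (Homo sapiens) for antiproliferative activity, read by MTT assay, with a stated time of 48 h (on this read-out higher numbers stand for weaker inhibition and lower numbers for stronger inhibition), the lowest of the three numbers recorded. Compound 2 `COc1ccc(-c2nc3cccc(-c4cc(OC)c(OC)c(OC)c4)c3o2)cc1F` gives 1700 nM in this assay; the step of a 1.3-fold higher number from compound 1 to compound 2 (0.12 log units; within the scatter) lies within the scatter. Compound 3 `COc1cc(-c2cccc3nc(-c4cccc(O)c4)oc23)cc(OC)c1OC` gives 5500 nM in this assay, and the step of a 4.2-fold higher number from compound 1 to compound 3 (0.63 log units; beyond the scatter) is beyond the scatter, as is the step of a 3.2-fold higher number from compound 2 to compound 3 (0.51 log units; beyond the scatter).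

Compound 4 `COc1cc(-c2cccc3nc(-c4cccs4)oc23)cc(OC)c1OC` has not yet been measured. Relative to compound 1 the change is thiophen-2-yl in place of 3,4-dimethoxyphenyl on an aromatic carbon. The step that bears most directly on it is a 4.2-fold higher number from compound 1 to compound 3 (0.63 log units; beyond the scatter), where the same 3,4-dimethoxyphenyl was also replaced and the number rose modestly. The step of a 1.3-fold higher number from compound 1 to compound 2 (0.12 log units; within the scatter), a smaller alteration within that group, stayed within the scatter. Because a 4.2-fold higher number from compound 1 to compound 3 (0.63 log units; beyond the scatter) already showed a modest weakening when compound 1 lost this group, a weakening of similar or somewhat larger size is expected for compound 4, a step of a 3.5-fold higher number from compound 1 to compound 4 (0.54 log units; beyond the scatter). Compound 4 is therefore estimated at 4500 nM in this assay, within a range from 1500 nM to 14000 nM.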

Compound 4, half-maximal inhibitory concentration: 3000 nM
The estimate for compound 4 lay 1.5-fold (0.18 log units) above the measured number; the range from low to high includes it.
By their numbers in this assay, from the lowest: compounds 1, 2, 4 and 3 (each within the scatter of the next, the first and the last beyond it).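

At this position, on an aromatic carbon next to the ring nitrogen and next to the ring oxygen, a five-membered aromatic ring with sulfur can replace the larger 3,4-dimethoxyphenyl at modest cost in this assay with a 2.3-fold higher number from compound 1 to compound 4 (0.36 log units; beyond the scatter) as the step. Thiophen-2-yl is not separated from the other two replacements, as a 1.8-fold lower number from compound 3 to compound 4 (0.26 log units; within the scatter) and a 1.8-fold higher number from compound 2 to compound 4 (0.25 log units; within the scatter) both lie within the scatter. Compound 4 therefore joins compound 3 as a replacement beyond the scatter of compound 1, while compound 2 remains the only one within it.

Nothing available explains these differences. Going by these compounds, how a thiophen-3-yl, a furan-2-yl, or a phenyl ring carrying a carboxylic acid or an amine would read at this position remains open.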